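Aryl hydrazone variation on the shared core: compound 3

A few compounds are considered here, and "the series" means these few. Any claim that something is new, unique, unknown or untested is made for them only; others in the source may bear on it.

Compound 2 `CC1CC/C(=N\Nc2ccc(I)cc2)c2ncc(C(=O)O)c(=O)n21` stands, in a functional assay on the whole organism for inhibition, with Rattus norvegicus as the target (on this read-out higher numbers stand for an effect only at larger amounts of compound and lower numbers for an effect already at smaller amounts), at a limit of the assay: compound 2 gives > 1000 umol/kg. Compound 1 `CC1CC/C(=N\Nc2ccc(Br)cc2)c2ncc(C(=O)O)c(=O)n21` also sits at a limit in this assay, where compound 1 gives > 1000 umol/kg. The step that the two limits leave unreadable from compound 1 to compound 2 is thus not readable, and the limit of > 1000 umol/kg in this assay, at which 2 of the 2 values shown sit, covers both values. Compound 3 `COc1ccccc1N/N=C1\CCC(C)n2c1ncc(C(=O)O)c2=O` differs from compound 2 by 2-methoxyphenyl in place of 4-iodophenyl on an amine nitrogen. Going by the values given here, no measured step bears on this change. The expected step is a number no higher from compound 2 to compound 3 (the limit leaves the size open), with a limit again the most likely outcome. Compound 3 is estimated at 1000 umol/kg, expected between 300 umol/kg and 3000 umol/kg.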

Compound 3, dose for 50% inhibition: > 1000 umol/kg
Compound 3 ended at the assay's limit (the forecaster's own chance of this, stated with the estimate: 70%); the middle value lies on the limit itself.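

No step among compound 1, compound 2 and compound 3 can be read in this assay, as all three stand at a limit: the limit of > 1000 umol/kg in this assay, at which 3 of the 3 values shown sit.

The compounds shown leave open how 4-bromophenyl, 4-iodophenyl and 2-methoxyphenyl compare on the shared core.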